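The source may hold more compounds than are shown below. What is called first, only, known or untested is meant among the compounds shown, and "the series" means these compounds.

Compound 2 `CC#CC(CC(=O)O)c1ccc(OCc2ccc3nc(-c4ccccc4)cn3c2)cc1` stands at the upper end of the three numbers in an assay on isolated protein for agonist activity at Free fatty acid receptor 1 (Homo sapiens) (on this read-out lower numbers stand for an effect already at smaller amounts and higher numbers for an effect only at larger amounts of compound), giving 979 nM. Compound 1 `CC#CC(CC(=O)O)c1ccc(OCc2ccc3nc(-c4ccccc4C)cn3c2)cc1` gives 389 nM and compound 3 `CC#CC(CC(=O)O)c1ccc(OCc2ccn3cc(-c4ccccc4C)nc3c2)cc1` gives 459 nM. For the measured compounds named here, the one step through a single change is a 2.5-fold higher number from compound 1 to compound 2 (0.40 log units; beyond the scatter), a substituent on the same aromatic ring that carries the change considered here. Compound 4 `CC#CC(CC(=O)O)c1ccc(OCc2ccc3nc(-c4ccc(C5CCCCC5)cc4)cn3c2)cc1` is compound 2 with cyclohexyl in place of hydrogen on an aromatic carbon. Going by the values given here, no measured step puts a group of this size on that ring, so the only guide is compound 1, whose 389 nM lies modestly below the number for compound 2. Among the compounds with values here, a step of comparable size downward is expected, a 2.0-fold lower number from compound 2 to compound 4 (0.29 log units; within the scatter), with a wide range because no direct precedent exists. For compound 4 the estimate is 500 nM, between 150 nM and 2500 nM.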

Compound 4, half-maximal effective concentration: 417 nM
Compound 4: the middle estimate sits 1.2-fold (0.08 log units) above what was measured, and the stated range covers the measured number.
By their numbers in this assay, from the lowest: compounds 1, 4 and 3 (each within the scatter of the next); then compound 2.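

On the phenyl ring, cyclohexyl on an aromatic carbon para to a large group gives a 2.3-fold lower number from compound 2 to compound 4 (0.37 log units; beyond the scatter) in this assay, so a substituent this large is accepted at this position with no loss. Replacing 2-methylphenyl with 4-cyclohexylphenyl gives a 1.1-fold higher number from compound 1 to compound 4 (0.03 log units; within the scatter), so these two substituted rings cannot be told apart on this read-out. No available data explain this match.

Still open, going by these compounds, is whether a methyl or an amine at the cyclohexyl position would give a similar number. Also open, on these data alone, is whether cyclohexyl would behave the same way on the core of compound 3.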